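Sulfonate esters with aryl ureas: swapping the phenyl group

The compounds below may be only part of what the source reports. "The series", "measured", "known", "first", "only" and "open" are said of these compounds alone.

Measured so far:
compound 1 `CCNC(=O)Nc1ccc(S(=O)(=O)Oc2ccccc2C)cc1` gives 3100 nM in a functional assay on M21 cells (Homo sapiens) for cytotoxicity, read by sulforhodamine B assay, with a stated time of 48 h; on this read-out lower numbers stand for stronger inhibition and higher numbers for weaker inhibition
compound 2 `CCNC(=O)Nc1ccc(S(=O)(=O)Oc2ccccc2CC)cc1` gives 2500 nM in this assay

Compound 2 holds the lowest of the two numbers, and the step of a 1.2-fold lower number from compound 1 to compound 2 (0.09 log units; within the scatter) is within the scatter, so the two compounds are not told apart. Compound 3 `CCNC(=O)Nc1ccc(S(=O)(=O)Oc2ccc(O)cc2)cc1` brings a different change: 4-hydroxyphenyl in place of 2-ethylphenyl on an oxygen. Among the compounds with values here, no measured step touches this kind of exchange; the only one known, a 1.2-fold lower number from compound 1 to compound 2 (0.09 log units; within the scatter), stays within the scatter and says nothing about a hydroxyl on the ring. Compound 3 is therefore expected to lie close to compound 2, with the estimated step of a 1.2-fold higher number from compound 2 to compound 3 (0.08 log units; within the scatter) and a wide range. Compound 3 is estimated at 3000 nM, between 800 nM and 12000 nM.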

Compound 3, half-maximal inhibitory concentration: 4300 nM
Compound 3: the middle estimate sits 1.4-fold (0.16 log units) below what was measured, within the range that was stated.
By their numbers in this assay, from the lowest: compounds 2, 1 and 3 (each within the scatter of the next).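

On the oxygen bound to the sulfonyl sulfur, 4-hydroxyphenyl replaces 2-ethylphenyl with a 1.7-fold higher number from compound 2 to compound 3 (0.24 log units; within the scatter) and replaces 2-methylphenyl with a 1.4-fold higher number from compound 1 to compound 3 (0.14 log units; within the scatter) in this assay. So a ring with a hydrogen-bond donor and acceptor can stand at this place without a difference that can be told from the scatter. No available evidence gives a reason for this result. Still open, from the compounds shown here alone, is what an amine or a carboxylic acid would give in place of the hydroxyl, or a longer chain on the ring.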